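This account rests on a few compounds, and the source may have more. Where it says the series, first, only, none or still open, it means among the compounds named here.

Measured in a functional assay on M21 cells (Homo sapiens) for cytotoxicity, read by sulforhodamine B assay, with a stated time of 48 h; on this read-out lower numbers stand for stronger inhibition and higher numbers for weaker inhibition:
- compound 1 `CCCc1ccccc1NS(=O)(=O)c1cccc(NC(=O)NCCCCl)c1`: 23000 nM
- compound 2 `CCNC(=O)Nc1cccc(S(=O)(=O)Nc2ccccc2C)c1`: 131000 nM

Compound 2 stands highest of the two at 131000 nM, the weaker result, and its gap to compound 1 lies beyond the scatter. Compound 3 `CCCc1ccccc1NS(=O)(=O)c1cccc(NC(=O)NCC)c1` differs from compound 2 by ethyl in place of hydrogen on a saturated chain carbon bound to an aromatic carbon. A moderate step to a lower number is expected in this assay, since compound 1, which also carries the propyl, gives 23000 nM. The estimated value for compound 3 is 55000 nM, with an expected range of 22000 nM to 130000 nM. This estimate means an expected 2.4-fold lower number from compound 2 to compound 3 (0.38 log units; beyond the scatter).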

Compound 3, half-maximal inhibitory concentration: 60000 nM
For compound 3 the middle estimate is 1.1-fold (0.04 log units) below the measured one, and the stated range covers the measured number.
By their numbers in this assay, from the lowest: compound 1; then compound 3; then compound 2.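

In this assay, ethyl in place of hydrogen on a saturated chain carbon bound to an aromatic carbon gives a 2.2-fold lower number from compound 2 to compound 3 (0.34 log units; beyond the scatter) on its own, so this position moves the read-out while the rest of the molecule stays fixed. Hydrogen in place of chloromethyl on a saturated chain carbon, two bonds along the chain from an amide-type nitrogen, gives a 2.6-fold higher number from compound 1 to compound 3 (0.42 log units; beyond the scatter) as a separate, modest step. No available evidence bears on either step.
Going by these compounds, whether a butyl chain or an amine on the saturated chain carbon bound to an aromatic carbon would continue this trend stays open.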